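The source may hold more compounds than are shown below. What is called first, only, known or untested is meant among the compounds shown, and "the series" means these compounds.

Measured in a functional assay on HepG2 cells (Homo sapiens) for inhibition, read by MTT assay, with a stated time of 48 h; on this read-out lower numbers stand for stronger inhibition and higher numbers for weaker inhibition:
- compound 1 `Brc1ccccc1CSc1nnc(-c2ccncc2)n1-c1ccccc1` gives 17100 nM
- compound 2 `Clc1cccc(CSc2nnc(-c3ccncc3)n2-c2ccccc2)c1` gives 11200 nM
- compound 3 `Fc1cccc(F)c1CSc1nnc(-c2ccncc2)n1-c1ccccc1` gives > 50000 nM (a limit of the assay)

Compound 3 has the limit > 50000 nM in this assay and no number. The next change leads to compound 4 `O=[N+]([O-])c1ccc(CSc2nnc(-c3ccncc3)n2-c2ccccc2)cc1` and reads 4-nitrophenyl in place of 2,6-difluorophenyl on a saturated chain carbon bound to a sulfur in this series: 4-nitrophenyl in place of 2,6-difluorophenyl on a saturated chain carbon bound to a sulfur.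

Two measured steps enter the group that leaves here: an at least 2.9-fold higher number from compound 1 to compound 3 (0.46 log units; beyond the scatter) and an at least 4.4-fold higher number from compound 2 to compound 3 (0.64 log units; beyond the scatter) on the second route. As far as these compounds go, both end at the limit, so their true sizes remain open. The third step, a 1.5-fold lower number from compound 1 to compound 2 (0.18 log units; within the scatter), separates the other two phenyl groups by no real margin. Going by the values given here, no measured compound carries 4-nitrophenyl, so these steps speak only to the loss of 2,6-difluorophenyl, and the entering group remains untested.

Among the compounds with values here, with compound 1 at 17100 nM and compound 2 at 11200 nM as the only numbers available, compound 4 is expected to return toward them. The expected change is an at least 2.7-fold lower number from compound 3 to compound 4 (0.44 log units; beyond the scatter) and is a modest one, with a renewed limit still possible. The estimate for compound 4 is 18000 nM within an expected range of 7000 nM to 50000 nM in this assay here.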

Compound 4, half-maximal inhibitory concentration: > 50000 nM
Compound 4: no number, only a limit; the forecaster's own chance of this, stated with the estimate: 20%; middle value at least 2.7-fold (0.44 log units) from the limit.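

In this assay, compound 4 gives > 50000 nM, a limit of the assay and not a number. At this place, on a saturated chain carbon bound to a sulfur, 4-nitrophenyl stands clearly apart from both groups that gave numbers, with an at least 4.4-fold higher number from compound 2 to compound 4 (0.64 log units; beyond the scatter) and an at least 2.9-fold higher number from compound 1 to compound 4 (0.46 log units; beyond the scatter), so the loss of a measurable value in this assay is no longer confined to 2,6-difluorophenyl. The step between compound 3 and compound 4 cannot be read, and the series now splits into two compounds with numbers and two at the same limit: the limit of > 50000 nM in this assay, at which 2 of the 4 values shown sit.

As far as these compounds go, how far compound 3 and compound 4 lie past the limit stays open, and with it any order between them, while the step from compound 1 to compound 2 stays within the scatter and gives no order either. Also open, from the compounds shown here alone, is whether an amine or a carboxylic acid on the phenyl group at this place would give a number in this assay, and whether any group here would give a value clearly lower than those of compound 1 and compound 2.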